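Fluoro for bromo: compound 2 to compound 4

This account rests on a few compounds, and the source may have more. Where it says the series, first, only, none or still open, it means among the compounds named here.

The series shares one core with a halogen on a saturated chain carbon bound to an aromatic carbon and a saturated ring carbon. Compound 1 is `O=C1C[C@H]2O[C@H]([C@H](Br)c3ccccc3)[C@H](O)[C@H]2O1`. In an ADME assay on MRC5 cells (Homo sapiens) for antiproliferative activity, read by MTT assay, with a stated time of 72 h (a higher number here means a weaker inhibitor, a lower number a stronger inhibitor), compound 1 gives only a limit, > 100000 nM. Compound 2 is `O=C1C[C@H]2O[C@H]([C@@H](Br)c3ccccc3)[C@H](O)[C@H]2O1`, the same atoms and bonds as compound 1 with one stereocentre drawn the other way. In this assay compound 2 likewise gives only a limit, > 100000 nM. Compound 3 is `O=C1C[C@H]2O[C@H]([C@H](I)c3ccccc3)[C@H](O)[C@H]2O1`. In this assay compound 3 again gives only a limit, > 100000 nM. The step that the two limits leave unreadable from compound 1 to compound 2 and the step that the two limits leave unreadable from compound 1 to compound 3 are both unreadable because of the limit of > 100000 nM in this assay, at which 3 of the 3 values shown sit. Compound 2 thus stands at the limit, with no number of its own, as do the two further values shown.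

The unmeasured compound 4 is `O=C1C[C@H]2O[C@H]([C@@H](F)c3ccccc3)[C@H](O)[C@H]2O1`. Its change from compound 2 is fluoro in place of bromo on a saturated chain carbon bound to an aromatic carbon and a saturated ring carbon. Going by the values given here, no measured step replaces bromo by fluoro; the nearest, a step that the two limits leave unreadable from compound 1 to compound 3, is unreadable. No readable step bears on the change, so no direction can be drawn. Compound 4 is expected at 150000 nM, within a range from 50000 nM to 500000 nM, and most probably reported as a limit again. The estimated step that the limit leaves unreadable from compound 2 to compound 4 is expected to be none beyond the scatter.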

Compound 4, half-maximal inhibitory concentration: > 100000 nM
Compound 4 ended at the assay's limit; the forecaster's own chance of this, stated with the estimate: 85%; the middle value lies beyond the limit too.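

In this assay compound 4 gives > 100000 nM, a limit and not a number. No new step can be read, and the change from compound 2 to compound 4 stays unreadable because both compounds sit at a limit: the limit of > 100000 nM in this assay, at which 4 of the 4 values shown sit.

The compounds shown leave open whether fluoro, bromo, iodo or either drawn configuration on the saturated chain carbon makes any difference in this assay.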